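This account rests on a few compounds, and the source may have more. Where it says the series, first, only, none or still open, it means among the compounds named here.

The compounds share one core and differ in the group on a thiocarbonyl carbon. In a functional assay on MCF7 cells (Homo sapiens) for antiproliferative activity, read by MTT assay, with a stated time of 96 h (on this read-out lower numbers stand for stronger inhibition and higher numbers for weaker inhibition), compound 1 (`CSC(=S)N/N=C1\CC2(CCCCC2)Oc2c1ccc1ccccc21`), with methylsulfanyl at that place, gives 5100 nM, and compound 2 (`S=C(N/N=C1\CC2(CCCCC2)Oc2c1ccc1ccccc21)N1CCNCC1`), with piperazin-1-yl, gives 14200 nM. Compound 2 therefore has the higher of the two numbers and is the weaker inhibitor of the pair. Within the data shown here, the only measured step, a 2.8-fold higher number from compound 1 to compound 2 (0.44 log units; beyond the scatter), is modest but beyond the scatter.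

Compound 3 (`S=C(N/N=C1\CC2(CCCCC2)Oc2c1ccc1ccccc21)N1CCOCC1`) carries morpholin-4-yl in place of piperazin-1-yl on a thiocarbonyl carbon. Among the measured compounds shown here, no measured step exchanges one of these rings for the other, so the single step at this carbon is only a rough guide to size. For the measured compounds named here, a change between two six-membered rings is expected to be no larger than that step. The direction is uncertain, with a slight lean towards lower numbers, as compound 1 stands at 5100 nM. The expected change in this assay is a 1.5-fold lower number from compound 2 to compound 3 (0.17 log units; within the scatter). Compound 3 is estimated at 9500 nM, with an expected range of 4000 nM to 23000 nM.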

Compound 3, half-maximal inhibitory concentration: 11900 nM
Compound 3: the middle estimate sits 1.3-fold (0.10 log units) below what was measured; the range from low to high includes it.
By their numbers in this assay, from the lowest: compound 1; then compounds 3 and 2 (each within the scatter of the next).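

In this assay, morpholin-4-yl in place of piperazin-1-yl gives a 1.2-fold lower number from compound 2 to compound 3 (0.08 log units; within the scatter), so at this thiocarbonyl carbon the two rings cannot be told apart, even though an oxygen takes the place of a ring nitrogen and the hydrogen-bond donor of piperazin-1-yl is gone. The step from methylsulfanyl to morpholin-4-yl, a 2.3-fold higher number from compound 1 to compound 3 (0.37 log units; beyond the scatter), runs the same way as a 2.8-fold higher number from compound 1 to compound 2 (0.44 log units; beyond the scatter), so the higher number relative to compound 1 is now seen with two different six-membered rings rather than with piperazin-1-yl alone. Nothing available explains this difference between methylsulfanyl and the two rings, or the closeness of the rings to each other.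

The compounds shown leave open whether the higher numbers belong to six-membered rings as such or would also appear with an open-chain group such as dimethylamino or a simple amino group at this carbon. They also leave open whether a longer thioether such as ethylsulfanyl or benzylsulfanyl would stay near compound 1, and whether a methyl group on the free ring nitrogen of compound 2 would change its number.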